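The source may hold more compounds than are shown below. What is called first, only, known or untested is meant among the compounds shown, and "the series" means these compounds.

The series shares one core, and its growth-inhibiting power is read in a functional assay on U-251 cells (Homo sapiens) for inhibition, read by sulforhodamine B assay, with a stated time of 48 h; a lower number here means a stronger inhibitor of growth, a higher number a weaker inhibitor of growth. Compound 1 `N#C/C(=C\N1CCN(C(=O)c2ccco2)C1=S)C(=O)Nc1ccc(Cl)cc1` gives 17300 nM. Compound 2 `N#C/C(=C\N1CCN(C(=O)c2ccco2)C1=S)C(N)=O`, where hydrogen stands in place of 4-chlorophenyl on an amide-type nitrogen, gives 11500 nM. The step of a 1.5-fold lower number from compound 1 to compound 2 (0.18 log units; within the scatter) lies within the scatter, so compound 2 and compound 1 cannot be told apart on these numbers; both are weak inhibitors of growth.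

Compound 3 `N#C/C(=C\N1CCN(C(=O)c2ccco2)C1=S)C(=O)c1ccccc1` carries phenyl in place of amino on a carbonyl carbon. Within the data shown here, no measured step changes the carbonyl carbon itself; the only step available, a 1.5-fold lower number from compound 1 to compound 2 (0.18 log units; within the scatter), alters the same carboxamide end without a shift beyond the scatter. Compound 3 is therefore expected to stay near compound 2, with no step beyond the scatter in this assay, the estimated step being a 1.0-fold higher number from compound 2 to compound 3 (0.02 log units; within the scatter). The estimate for compound 3 is 12000 nM, with a range from 4000 nM to 36000 nM.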

Compound 3, concentration for 50% growth inhibition: 17000 nM
Estimate against measurement, compound 3: 1.4-fold (0.15 log units) below; the range from low to high includes it.
By their numbers in this assay, from the lowest: compounds 2, 3 and 1 (each within the scatter of the next).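

In this assay, putting phenyl in place of amino on the carbonyl carbon, which turns carbamoyl into benzoyl, gives a 1.5-fold higher number from compound 2 to compound 3 (0.17 log units; within the scatter), while phenyl in place of (4-chlorophenyl)amino gives a 1.0-fold lower number from compound 1 to compound 3 (0.01 log units; within the scatter). This position has now carried amino, (4-chlorophenyl)amino and phenyl, and even the swap that removes the nitrogen attached to this carbonyl carbon produces no shift beyond the scatter, so none of the three compounds can be told apart. No supporting evidence is available to explain this flat result.

Going by these compounds, whether another group on this carbonyl carbon, such as a hydroxyl, which would make a carboxylic acid, or a morpholine ring, would shift the reading beyond the scatter remains open. On these data alone, all three compounds also share the rest of the core, so the effect of changes elsewhere remains unknown.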